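The compounds below may be only part of what the source reports. "The series", "measured", "known", "first", "only" and "open" are said of these compounds alone.

Working notes on the series, all read in a functional assay on PC-3 cells (Homo sapiens) for inhibition, read by sulforhodamine B assay, with a stated time of 48 h, tested at 50 uM; on this read-out higher numbers stand for more inhibition of growth at the one concentration tested and lower numbers for less inhibition of growth. Compound 1 (`CCCOc1ccc([C@@H]2CC(=O)c3cc(CC=C(C)C)c(OC)cc3O2)cc1`) gives 54% and compound 3 (`COc1cc2c(cc1CC=C(C)C)C(=O)C[C@@H](c1ccc(Oc3cccc([N+](=O)[O-])c3)cc1)O2`) gives 21% on the same read-out. Compound 2 (`COc1ccc([C@@H]2C/C(=N/OCc3cn(-c4ccc(C(=O)c5ccccc5)cc4)nn3)c3cc(CC=C(C)C)c(OC)cc3O2)cc1`) gives 40% and so sits second of the three, below compound 1 and above compound 3, with both gaps beyond the scatter.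

The next step leads to compound 4 (`COc1ccc([C@@H]2C/C(=N/OCc3cn(-c4ccc(NC(=O)c5ccccc5)cc4)nn3)c3cc(CC=C(C)C)c(OC)cc3O2)cc1`). The change is benzamido in place of benzoyl on an aromatic carbon and amounts to benzamido in place of benzoyl on an aromatic carbon, para to a large group. Going by the values given here, no measured pair carries this exchange, so direct evidence is lacking.

Among the compounds with values here, the only measured step, a number 33 percentage points lower from compound 1 to compound 3 (beyond the scatter), is 3-nitrophenyl in place of propyl on an oxygen on an aromatic ring. It lies elsewhere on the molecule and gives no direction for compound 4, though its size argues for a wide range.

No step beyond the scatter is therefore expected in this assay. The estimated step is a number 2 percentage points lower from compound 2 to compound 4 (within the scatter) (an expectation only). For compound 4 the estimated value is 38% (expected range 22% to 54%).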

Compound 4, percent growth inhibition at one concentration: 22%
Compound 4: the middle estimate sits 16 percentage points above what was measured; measured number inside the range.
By their numbers in this assay, from the lowest: compounds 3 and 4 (each within the scatter of the next); then compound 2; then compound 1.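

In this assay, going by these compounds alone, this is the first measured change at this end of the molecule, and benzamido in place of benzoyl on an aromatic carbon, para to a large group, is not a neutral exchange: a number 18 percentage points lower from compound 2 to compound 4 (beyond the scatter). Both groups hold a six-membered aromatic ring of carbon only and a double bond outside aromatic rings, while benzamido adds a nitrogen and a hydrogen-bond donor, so the read-out responds to a change confined to how the terminal ring is attached. No available measurement accounts for the direction or size of this step.

The two compounds do not separate the contribution of the added nitrogen from that of the amide hydrogen, a question that a methyl group on the amide nitrogen would address, and they do not show how an amine, a carboxylic acid or a longer chain would read out at the same place. As far as these compounds go, it also remains open whether the same exchange would give a similar step in other cell lines or at other concentrations.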